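Adding a Methyl to the Amide Nitrogen of Compound 2

The source may report more compounds than this note shows. Statements on the series, on what has been measured and on what is new or still open speak of the compounds shown alone.

- compound 1 `CN(C)/C(=N\C#N)C1=CC(C)(C)Oc2ccc([N+](=O)[O-])cc21`: 51.3 nM
- compound 2 `CNC(=O)C1=CC(C)(C)Oc2ccc([N+](=O)[O-])cc21`: 33.1 nM

Both values come from a functional assay on the whole organism for inhibition, with Cavia porcellus as the target; on this read-out lower numbers stand for an effect already at smaller amounts and higher numbers for an effect only at larger amounts of compound. Within the data shown here, only two numbers exist so far, and compound 2, at 33.1 nM, cannot be separated from compound 1. The step between them, a 1.5-fold lower number from compound 1 to compound 2 (0.19 log units; within the scatter), is a large exchange of groups on a double-bonded ring carbon, yet it leaves the read-out within the normal scatter.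

The next molecule is compound 3 `CN(C)C(=O)C1=CC(C)(C)Oc2ccc([N+](=O)[O-])cc21`. It has methyl in place of hydrogen on an amide-type nitrogen, so methylcarbamoyl becomes dimethylcarbamoyl.

Among the measured compounds shown here, no measured step tests this exact change, so the evidence is indirect. For the measured compounds named here, the one measured step is small, and compound 1, at 51.3 nM, already carries a dimethylamino group. No step beyond the scatter is therefore expected in this assay, though a drift towards a higher number would be no surprise, and the lack of a direct comparison calls for a wide range. The expected change is a 1.8-fold higher number from compound 2 to compound 3 (0.26 log units; within the scatter). For compound 3 the estimated value is 60 nM, with an expected range from 15 nM to 300 nM.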

Compound 3, half-maximal effective concentration: 398 nM
Beside the measured number, compound 3's estimate is 6.6-fold (0.82 log units) below it, and the stated range ends below it.
By their numbers in this assay, from the lowest: compounds 2 and 1 (each within the scatter of the next); then compound 3.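

In this assay, the amide-type nitrogen proves far more sensitive than the earlier pair suggested: a single methyl in place of the amide hydrogen, turning methylcarbamoyl into dimethylcarbamoyl, gives a large step (a 12-fold higher number from compound 2 to compound 3 (1.08 log units; beyond the scatter)). That one added carbon does what the much bigger exchange of groups on the double-bonded ring carbon did not do, since that exchange stayed within the scatter. A dimethylamino group alone does not go with a high number, however: exchanging the nitrile-bearing group for dimethylcarbamoyl, which keeps a dimethylamino unit but attaches it to a carbonyl carbon, gives a modest step of its own (a 7.8-fold higher number from compound 1 to compound 3 (0.89 log units; beyond the scatter)), so what that unit is attached to matters as well. No measurement here speaks to the reason for either step.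

Going by these compounds, it remains open whether the rise follows the loss of the amide hydrogen or the added carbon, a question that an ethyl group on the amide nitrogen or a plain carbamoyl group with two hydrogens on the nitrogen could help to settle. On these data alone, it also remains open how a carboxylic acid at this place would read, and whether a methylamino version of the nitrile-bearing group would behave like compound 2.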